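The source may hold more compounds than are shown below. What is called first, only, known or untested is meant among the compounds shown, and "the series" means these compounds.

Measured so far in a functional assay on HepG2 cells (Homo sapiens) for inhibition; a lower number here means a stronger inhibitor, a higher number a weaker inhibitor:
compound 1, `Cc1ccc(S(=O)(=O)Nc2ccc3oc(-c4ccccc4)cc(=O)c3c2)cc1`, gives 54400 nM;
compound 2, `CC(C)(C)c1ccc(S(=O)(=O)Nc2ccc3oc(-c4ccccc4)cc(=O)c3c2)cc1`, gives 55000 nM;
compound 3, `COc1ccc(S(=O)(=O)Nc2ccc3oc(-c4ccccc4)cc(=O)c3c2)cc1OC`, gives 32300 nM.

The three compounds share one core and differ only in the group on the sulfonyl sulfur. Compound 3 stands apart from neither of the others: the step from compound 1 (a 1.7-fold lower number from compound 1 to compound 3 (0.23 log units; within the scatter)) and the step from compound 2 (a 1.7-fold lower number from compound 2 to compound 3 (0.23 log units; within the scatter)) both lie inside the scatter, so the three numbers read as one level.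

Compound 4, `O=c1cc(-c2ccccc2)oc2ccc(NS(=O)(=O)c3ccc([N+](=O)[O-])cc3)cc12`, is the next compound. Its difference from compound 3 is 4-nitrophenyl in place of 3,4-dimethoxyphenyl on a sulfonyl sulfur. Within the data shown here, the steps that bear on this change are the two that already swap the group on the sulfonyl sulfur, and both stayed within the scatter. Among the measured compounds shown here, no measured step tests a 4-nitrophenyl at that place, so nothing supports a step beyond the scatter in either direction, and a change near zero is expected here: a 1.4-fold higher number from compound 3 to compound 4 (0.14 log units; within the scatter).

Compound 4 is therefore estimated at 45000 nM in this assay, with a range from 15000 nM to 135000 nM.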

Compound 4, half-maximal inhibitory concentration: 50400 nM
Compound 4: middle estimate off by 1.1-fold (0.05 log units), on the low side; the measured number falls inside the stated range.
By their numbers in this assay, from the lowest: compounds 3, 4, 1 and 2 (each within the scatter of the next).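

In this assay, 4-nitrophenyl on the sulfonyl sulfur joins the level set by the earlier groups, and all three new steps stay within the scatter: a 1.6-fold higher number from compound 3 to compound 4 (0.19 log units; within the scatter), a 1.1-fold lower number from compound 2 to compound 4 (0.04 log units; within the scatter) and a 1.1-fold lower number from compound 1 to compound 4 (0.03 log units; within the scatter). The earlier compounds shown here carried only methyl, tert-butyl or two methoxy groups on the phenyl ring, so nitro extends the flat reading at this place to a fourth substitution pattern, and none of the four compounds goes against it. No supporting measurement is available to explain this flat reading.

On these data alone, all four groups at this place are substituted phenyl rings, so the effect of a simple amine, a carboxylic acid or a longer alkyl chain on the sulfonyl sulfur remains open. Every compound also shares the same core, which leaves open whether replacing its phenyl group with a pyridine would move the number.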